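The source may hold more compounds than are shown below. What is called first, only, known or untested is meant among the compounds shown, and "the series" means these compounds.

Measured in an ADME assay on microsomes from liver (Homo sapiens) for metabolic stability, read by LC-MS, using NADPH, with a stated time of 30 min, tested at 0.1 uM; a lower number here means that less of the compound is left, a higher number that more of the compound is left:
- Compound 1 `O=S(=O)(CCO)c1cccc(-c2ccc3nccc(-c4ccncc4)c3n2)c1`: 95%
- Compound 2 `O=S(=O)(NCCO)c1cccc(Nc2ccc3nccc(-c4ccncc4)c3n2)c1`: 59%

For the measured compounds named here, only two compounds have numbers so far. Compound 1 holds the higher one. The gap to compound 2 lies beyond the usual scatter of repeated measurements. These two compounds differ in more than one place, so their gap cannot be tied to any single structural change.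

The next compound is compound 3 `C[C@@H]1CN(S(=O)(=O)c2cccc(-c3ccc4nccc(-c5ccncc5)c4n3)c2)C[C@H](C)N1`, which keeps the core of compound 1 and changes one group: 3,5-dimethylpiperazin-1-yl in place of 2-hydroxyethyl on a sulfonyl sulfur. Going by the values given here, no measured pair shows this exchange, so any expectation remains loose. Compound 1, at 95%, leaves little room for a rise in this assay. Compound 2, at 59%, shows that a compound sharing this core can sit much lower. A moderate fall, larger than the scatter, is therefore expected, although a result close to compound 1 would be no surprise. The estimated change is a number 20 percentage points lower from compound 1 to compound 3 (beyond the scatter). For compound 3 the expected value is 75%, with an estimated range from 50% to 95%.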

Compound 3, percent of the compound remaining: 34%
Estimate against measurement, compound 3: 41 percentage points above; measured number outside the range, below it.
By their numbers in this assay, from the lowest: compound 3; then compound 2; then compound 1.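

In this assay, the group on the sulfonyl sulfur proves to matter greatly: with the rest of the molecule unchanged, exchanging 2-hydroxyethyl for 3,5-dimethylpiperazin-1-yl gives a number 61 percentage points lower from compound 1 to compound 3 (beyond the scatter) in this first comparison that differs in one place only. The core of compound 1 therefore does not secure a high number by itself, as compound 3 keeps that core and gives 34% even though the hydrogen-bond donor and acceptor counts of the two groups match and neither group has a net charge. The new group does differ in having 8 heavy atoms rather than 3 and in bringing a ring and defined stereocentres, but no measurement here explains the fall.

As far as these compounds go, it remains open whether the fall follows the ring itself, the methyl groups or their stereochemistry. An unsubstituted piperazine, a morpholine or a longer chain such as 3-hydroxypropyl on the same sulfonyl sulfur would help separate these possibilities.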